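The source may hold more compounds than are shown below. What is called first, only, known or untested is meant among the compounds shown, and "the series" means these compounds.

Among the measured compounds shown here, compound 3 `CCn1c(C(=O)N(C)CCC#N)ccc1C(CC)(CC)c1ccc(OCC(O)C(C)(C)C)c(C)c1` gives 1960 nM in an assay on HL-60 cells for agonist activity at vitamin D3 receptor (Homo sapiens), read by microscopy, with a stated time of 96 h (on this read-out higher numbers stand for an effect only at larger amounts of compound and lower numbers for an effect already at smaller amounts), the highest of the three numbers known. Compound 1 `CC[C@@H](C)[C@H](NC(=O)c1ccc(C(CC)(CC)c2ccc(OCC(O)C(C)(C)C)c(C)c2)n1CC)C(=O)OC` gives 26 nM and compound 2 `CCn1c(C(=O)NCCN(C)C)ccc1C(CC)(CC)c1ccc(OCC(O)C(C)(C)C)c(C)c1` gives 14 nM, separated by the step of a 1.9-fold lower number from compound 1 to compound 2 (0.27 log units; within the scatter). Both carry an amide hydrogen, whereas compound 3 carries a methyl on that nitrogen, and the steps of a 75-fold higher number from compound 1 to compound 3 (1.88 log units; beyond the scatter) and a 140-fold higher number from compound 2 to compound 3 (2.15 log units; beyond the scatter) were large. Compound 4 `CCn1c(C(=O)N(C)c2ccccc2)ccc1C(CC)(CC)c1ccc(OCC(O)C(C)(C)C)c(C)c1` keeps that methyl; its difference from compound 3 is phenyl in place of 2-cyanoethyl on an amide-type nitrogen. For the measured compounds named here, no measured pair exchanges a phenyl for a 2-cyanoethyl there, so no step bears directly on this change; the two large steps show only that the one measured methyl-bearing amide was weak. The step of a 2.2-fold lower number from compound 3 to compound 4 (0.34 log units; beyond the scatter) is therefore expected to be small. Compound 4 is estimated at 900 nM, within 150 nM to 5000 nM.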

Compound 4, half-maximal effective concentration: 6400 nM
The estimate for compound 4 lay 7.1-fold (0.85 log units) below the measured number, outside the stated range (above it).
By their numbers in this assay, from the lowest: compounds 2 and 1 (each within the scatter of the next); then compound 3; then compound 4.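

Phenyl in place of 2-cyanoethyl on the amide-type nitrogen moves the number further up, a modest change (a 3.3-fold higher number from compound 3 to compound 4 (0.51 log units; beyond the scatter)), so a second methyl-bearing amide also falls far from the two amides with the amide hydrogen. The gaps to those two are large (a 460-fold higher number from compound 2 to compound 4 (2.66 log units; beyond the scatter); a 250-fold higher number from compound 1 to compound 4 (2.39 log units; beyond the scatter)), though each step also exchanges the rest of the substituent. Nothing available explains the difference between phenyl and 2-cyanoethyl here. Open remains whether the methyl alone accounts for these gaps. Also open, on these data alone, is whether a methyl-bearing amide carrying a carboxylic acid or a longer chain would stand nearer compound 2.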